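The source may report more compounds than this note shows. Statements on the series, on what has been measured and on what is new or still open speak of the compounds shown alone.

Compound 1 `c1cncc(CNCCCCN(C[C@H]2Cc3ccccc3CN2)[C@H]2CCCc3cccnc32)c1` — a limit, > 30000 nM
Compound 2 `c1ccc2c(c1)CN[C@@H](CN(CCCCNCC1CCOCC1)[C@H]1CCCc3cccnc31)C2` — a limit, > 30000 nM
Compound 3 `FC1(F)CCC(NC/C=C/CN(C[C@H]2Cc3ccccc3CN2)[C@H]2CCCc3cccnc32)CC1` — a limit, > 30000 nM

In a functional assay on cells for agonist activity at C-X-C chemokine receptor type 4 (Homo sapiens), read by fluorescence and calcium flux, with a stated time of 90 s (a lower number here means that less compound is needed, a higher number that more compound is needed for the effect), compound 1 gives only a limit, > 30000 nM. Compound 2 in this assay likewise gives only a limit, > 30000 nM. Compound 3 also returns only a limit in this assay, > 30000 nM. All three values therefore sit at the limit of > 30000 nM in this assay, at which 3 of the 3 values shown sit, and none of them is a number. Within the data shown here, the one step between measured compounds that differ in a single place, a step that the two limits leave unreadable from compound 1 to compound 2, exchanges a pyridin-3-yl for an oxan-4-yl, but with both ends at the limit its size cannot be read.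

Compound 4 `C(=C/CN(C[C@H]1Cc2ccccc2CN1)[C@H]1CCCc2cccnc21)\CNC1CCOCC1` differs from compound 3 by oxan-4-yl in place of 4,4-difluorocyclohexyl on an amine nitrogen. The step from compound 1 to compound 2 is the only one that bears on this change, since it too brings in an oxan-4-yl, and it gives no readable size. Compound 3 stands at the limit, and the change offers no measured reason to expect a departure from it. Compound 4 is thus expected to give 30000 nM in this assay, within 10000 nM to 100000 nM. The step from compound 3 to compound 4 is expected to be a number no higher from compound 3 to compound 4 (the limit leaves the size open), most likely again reported only as a limit.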

Compound 4, half-maximal effective concentration: > 30000 nM
Compound 4: no number, only a limit; the forecaster's own chance of this, stated with the estimate: 85%; the middle value sits exactly at the limit.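

In this assay compound 4 gives > 30000 nM as a limit and not a number. Its steps from compound 1, compound 2 and compound 3 therefore cannot be read: the limit of > 30000 nM in this assay, at which 4 of the 4 values shown sit. The compounds shown leave open whether any change to these side chains yields a measurable value at all.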